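The source may hold more compounds than are shown below. What is called first, only, known or untested is meant among the compounds shown, and "the series" means these compounds.

In a functional assay on K562 cells (Homo sapiens) for antiproliferative activity, with a stated time of 72 h (on this read-out higher numbers stand for weaker inhibition and lower numbers for stronger inhibition), compound 1 (`COc1ccc(CNc2ncnc3c2ncn3[C@@H]2O[C@H](CO)[C@@H](O)[C@H]2O)c(OC)c1`) gives > 166000 nM, a limit and not a number. Compound 2 (`COc1cc(CNc2ncnc3c2ncn3[C@@H]2O[C@H](CO)[C@@H](O)[C@H]2O)cc(OC)c1`) gives > 166000 nM, also a limit, so its standing is known only as that limit. Next in the series is compound 3 (`OC[C@H]1O[C@@H](n2cnc3c(NCc4ccc(F)cc4Cl)ncnc32)[C@H](O)[C@@H]1O`), and the change is 2-chloro-4-fluorophenyl in place of 3,5-dimethoxyphenyl on a saturated chain carbon bound to a nitrogen on an aromatic ring. Among the compounds with values here, the one measured step that bears on it is a step that the two limits leave unreadable from compound 1 to compound 2, with 3,5-dimethoxyphenyl in place of 2,4-dimethoxyphenyl, and it offers no size to carry over. Within the data shown here, the series so far shows only (the limit of > 166000 nM in this assay, at which 2 of the 2 values shown sit). Among the measured compounds shown here, no measured step guides the move to 2-chloro-4-fluorophenyl. Compound 3 is expected to stay at the same limit in this assay, and any number that does appear can only lie on the side of stronger inhibition. The expected step is an at least 1.6-fold lower number from compound 2 to compound 3 (0.22 log units; that floor lies within the scatter). Compound 3 is estimated at 100000 nM, with an expected range of 20000 nM to 166000 nM.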

Compound 3, half-maximal inhibitory concentration: 15600 nM
Estimate against measurement, compound 3: 6.4-fold (0.81 log units) above, outside the stated range (below it).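

In this assay, within the data shown here, the place on a saturated chain carbon bound to a nitrogen on an aromatic ring now proves able to shift the read-out, something the earlier compounds did not show. The move to 2-chloro-4-fluorophenyl gives an at least 10-fold lower number from compound 2 to compound 3 (1.02 log units; beyond the scatter), and against the other dimethoxyphenyl isomer it gives an at least 10-fold lower number from compound 1 to compound 3 (1.02 log units; beyond the scatter). The step between the two dimethoxyphenyl compounds cannot be read, as both stay at a limit: the limit of > 166000 nM in this assay, at which 2 of the 3 values shown sit.

The change replaces both ring substituents at once, so the compounds shown do not separate the contribution of chlorine from that of fluorine, or either from the loss of the methoxy groups. Also open, on these data alone, is how the read-out responds to a phenyl ring carrying only one halogen, or to a trifluoromethyl group or carboxylic acid on that ring.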